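A Methyl Branch Added Beside a Shorter Linker

This account rests on a few compounds, and the source may have more. Where it says the series, first, only, none or still open, it means among the compounds named here.

Compound 1 `CC1=C(CCC(=O)OCCCCOc2no[n+]([O-])c2S(=O)(=O)c2ccccc2)C(=O)c2c(O)cccc2C1=O` and compound 2 `CC1=C(C(C)CC(=O)OCCCCOc2no[n+]([O-])c2S(=O)(=O)c2ccccc2)C(=O)c2c(O)cccc2C1=O` share one core and differ in a single place. In a functional assay on A549 cells (Homo sapiens) for inhibition, read by MTT assay, with a stated time of 72 h (on this read-out lower numbers stand for stronger inhibition and higher numbers for weaker inhibition), compound 1 gives 8310 nM. In this assay compound 2 gives 19600 nM. The change from compound 1 to compound 2 is methyl in place of hydrogen on a saturated chain carbon bound to a double-bonded ring carbon and a saturated chain carbon, and it brought a 2.4-fold higher number from compound 1 to compound 2 (0.37 log units; beyond the scatter).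

Compound 3 `CC1=C(CCC(=O)OCCCOc2no[n+]([O-])c2S(=O)(=O)c2ccccc2)C(=O)c2c(O)cccc2C1=O` carries a second core; the difference between the two cores is not broken down here. In this assay compound 3 reaches only a limit, > 20000 nM, which is the limit of > 20000 nM in this assay, at which 1 of the 3 values shown sits.

Compound 4 `CC1=C(C(C)CC(=O)OCCCOc2no[n+]([O-])c2S(=O)(=O)c2ccccc2)C(=O)c2c(O)cccc2C1=O` has not yet been measured in this assay. It differs from compound 3 by methyl in place of hydrogen on a saturated chain carbon bound to a double-bonded ring carbon and a saturated chain carbon, the same change that was made from compound 1 to compound 2, at a place described in the same words. Because that change gave a 2.4-fold higher number from compound 1 to compound 2 (0.37 log units; beyond the scatter), one expects the number for compound 4 to rise rather than fall, and an expected step that the limit leaves unreadable from compound 3 to compound 4 is taken as the working guess. Since compound 3 already sits at a limit, the most likely outcome is that compound 4 is reported as a limit as well, and any number behind it is estimated at 45000 nM in this assay, with an expected range from 20000 nM to 120000 nM.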

Compound 4, half-maximal inhibitory concentration: 13900 nM
Compound 4: middle estimate off by 3.2-fold (0.51 log units), on the high side, outside the stated range (below it).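

In this assay, methyl in place of hydrogen on a saturated chain carbon bound to a double-bonded ring carbon and a saturated chain carbon gave a 2.4-fold higher number from compound 1 to compound 2 (0.37 log units; beyond the scatter) on the first core, but on the second core the same change gave an at least 1.4-fold lower number from compound 3 to compound 4 (0.15 log units; that floor lies within the scatter). Set side by side, the two steps show that the change did not carry over from one core to the other with the same direction, so the result on one core was a poor guide to the result on the other: the same change on two cores in this assay, a 2.4-fold higher number (0.37 log units; beyond the scatter) from compound 1 to compound 2 and an at least 1.4-fold lower number (0.15 log units; that floor lies within the scatter) from compound 3 to compound 4, at least 3.3-fold (0.53 log units) apart, beyond the scatter of two such steps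

Going by these compounds, compound 3 is reported only as a limit, > 20000 nM, so the actual size of the second step stays unknown, and these two pairs show neither why the outcomes part nor how the change would behave on any further core.

The compounds shown leave open whether a longer chain in the linker would follow the first step, the second, or neither. They also leave open whether an ethyl group in place of the methyl, or a carboxylic acid in place of the ester, would bring any further shift on either core.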